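Replacing the oxime hydroxy with butyl on the quinolinone imine

The compounds below may be only part of what the source reports. "The series", "measured", "known", "first", "only" and "open" are said of these compounds alone.

Measured compounds in a functional assay, read by spectrophotometry, with a stated time of 3 min; on this read-out lower numbers stand for stronger inhibition and higher numbers for weaker inhibition:
- compound 1, `Cc1ccc2[nH]c(=O)c(/C=N/O)cc2c1`: 38900 nM
- compound 2, `O=c1[nH]c2ccccc2cc1/C=N/O`: 31800 nM
- compound 3, `NS(=O)(=O)c1ccc(/N=C/c2cc3ccccc3[nH]c2=O)cc1`: 1610000 nM

Among the compounds with values here, compound 2 gives the lowest of the three numbers, but the only single-point step among them, a 1.2-fold lower number from compound 1 to compound 2 (0.09 log units; within the scatter), is within the scatter, so compounds 1 and 2 are not separable. Compound 3 stands far away from both; its number is higher than that of compound 2, a gap beyond the scatter, and the two structures differ at the double-bonded nitrogen, where compound 3 carries a substituted phenyl in place of the hydroxy.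

Compound 4, `CCCC/N=C/c1cc2ccccc2[nH]c1=O`, is the next compound to be measured in this assay. It differs from compound 2 by butyl in place of hydroxy on a double-bonded nitrogen. Within the data shown here, no measured step covers this exact change. Among the measured compounds shown here, the only relevant comparison is compound 2 against compound 3, which shows that exchanging the hydroxy on that nitrogen for a larger group without hydrogen-bond donors or acceptors goes with a much higher number; butyl is smaller than the group in compound 3, so a weaker version of that shift is expected. Compound 4 is therefore estimated at 150000 nM, within 40000 nM to 600000 nM, which would mean an expected step of a 4.7-fold higher number from compound 2 to compound 4 (0.67 log units; beyond the scatter).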

Compound 4, half-maximal inhibitory concentration: 1810000 nM
Compound 4: middle estimate off by 12-fold (1.08 log units), on the low side, and the stated range ends below it.
By their numbers in this assay, from the lowest: compounds 2 and 1 (each within the scatter of the next); then compounds 3 and 4 (each within the scatter of the next).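

In this assay, within the data shown here, the step of a 57-fold higher number from compound 2 to compound 4 (1.76 log units; beyond the scatter) is the first direct reading of a simple alkyl chain in place of the hydroxy on the double-bonded nitrogen, and it shows that this single exchange, with the shared core unchanged, is enough to produce a large change in the number. Compound 3 gives 1610000 nM and compound 4 gives 1810000 nM, values within the scatter of each other, so two quite different groups on this nitrogen, the substituted phenyl and butyl, cannot be told apart, and among the compounds shown only those keeping the hydroxy, compounds 1 and 2, hold the low numbers, with neither compound 3 nor compound 4 going against this. Nothing measured here on the compounds themselves accounts for the size of this step.

From the compounds shown here alone, it remains open whether a methoxy or an amino group on this nitrogen would stay close to compound 2 or fall with compounds 3 and 4. Going by these compounds, a chain as short as methyl is also open, as is whether butyl would have the same consequence on the methyl-bearing core of compound 1.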